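Acyl group variation on the piperazine-linked dioxolane amide series

The compounds below may be only part of what the source reports. "The series", "measured", "known", "first", "only" and "open" are said of these compounds alone.

Among the compounds with values here, compound 2 `O=C(CCc1ccccc1)Nc1ccc(N2CCN(c3ccc(OC[C@@H]4CO[C@@](Cn5cncn5)(c5ccc(Cl)cc5Cl)O4)cc3)CC2)cc1` holds the lower of the two numbers measured so far in a functional assay on A549 cells (Homo sapiens) for inhibition, read by MTT assay, with a stated time of 48 h; on this read-out lower numbers stand for stronger inhibition and higher numbers for weaker inhibition: compound 2 gives 2060 nM, whereas compound 1 `O=C(CC1CCOCC1)Nc1ccc(N2CCN(c3ccc(OC[C@@H]4CO[C@@](Cn5cncn5)(c5ccc(Cl)cc5Cl)O4)cc3)CC2)cc1` gives 10000 nM. Within the data shown here, the single measured step, a 4.9-fold lower number from compound 1 to compound 2 (0.69 log units; beyond the scatter), altered the group on the saturated chain carbon bound to the carbonyl carbon. Compound 3 `Cc1ccc(C(=O)Nc2ccc(N3CCN(c4ccc(OC[C@@H]5CO[C@@](Cn6cncn6)(c6ccc(Cl)cc6Cl)O5)cc4)CC3)cc2)o1` is not yet measured; it differs from compound 2 by 5-methylfuran-2-yl in place of phenethyl on a carbonyl carbon, so the whole acyl group is exchanged and an aromatic ring now sits on the carbonyl carbon. The step from compound 1 to compound 2 bears on this only loosely, since it changed the same region; it was modest and beyond the scatter. Among the measured compounds shown here, no measured pair tests an aromatic ring on the carbonyl carbon, so the direction is open. Compound 3 is estimated at 3500 nM, range 900 nM to 14000 nM, meaning an expected 1.7-fold higher number from compound 2 to compound 3 (0.23 log units; within the scatter).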

Compound 3, half-maximal inhibitory concentration: 4750 nM
Estimate against measurement, compound 3: 1.4-fold (0.13 log units) below, within the range that was stated.
By their numbers in this assay, from the lowest: compound 2; then compound 3; then compound 1.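

In this assay, a ring set directly on the carbonyl carbon can now be read: 5-methylfuran-2-yl in place of phenethyl gives a 2.3-fold higher number from compound 2 to compound 3 (0.36 log units; beyond the scatter) and so loses ground, while the same group in place of (oxan-4-yl)methyl gives a 2.1-fold lower number from compound 1 to compound 3 (0.32 log units; beyond the scatter) and so gains ground. The order at this position therefore does not follow a simple split into aromatic and saturated groups, and phenethyl remains the lowest of the three acyl substituents shown. Nothing available explains either step.

The compounds shown leave open how much of the step from phenethyl belongs to the ring type, to the methyl, or to the shorter link to the carbonyl carbon, since all three change together. Phenyl directly on the carbonyl carbon, or furan-2-yl without the methyl, would separate these.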